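The compounds below may be only part of what the source reports. "The series", "measured", "known", "first", "only" and "open" are said of these compounds alone.

Compound 1 `NC1=NC2(CCSCC2)N(OCCCOc2cccc(Cl)c2)C(N)=N1`: 260 nM
Compound 2 `Cc1ccc(OCCCON2C(N)=NC(N)=NC23CCOCC3)cc1`: 2580 nM

Of the two measured compounds, compound 2 stands at the higher number: in a functional assay on HL-60 cells (Homo sapiens) for antiproliferative activity, read by MTT assay, with a stated time of 72 h (a lower number here means a stronger inhibitor, a higher number a weaker inhibitor), compound 2 gives 2580 nM, while compound 1 gives 260 nM, a gap beyond the usual scatter. Compound 3 `NC1=NC2(CCOCC2)N(OCCCOc2ccccc2)C(N)=N1` differs from compound 2 in one place only: hydrogen in place of methyl on an aromatic carbon. Among the measured compounds shown here, no measured pair shows this change, and compound 1 differs in more than one place, so nothing here points a direction. The step from compound 2 to compound 3 in this assay is therefore expected to stay within the scatter, a 1.1-fold higher number from compound 2 to compound 3 (0.04 log units; within the scatter). Compound 3 is estimated at 2800 nM, between 1000 nM and 7500 nM.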

Compound 3, half-maximal inhibitory concentration: 2460 nM
Compound 3: the middle estimate sits 1.1-fold (0.06 log units) above what was measured; the measured number falls inside the stated range.
By their numbers in this assay, from the lowest: compound 1; then compounds 3 and 2 (each within the scatter of the next).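

Among the compounds shown here, this pair gives the first reading at this position: with 4-methylphenyl replaced by phenyl, this assay shows a 1.0-fold lower number from compound 2 to compound 3 (0.02 log units; within the scatter). On this aromatic carbon, para to a large group, methyl and hydrogen therefore cannot be told apart in this assay. Nothing available offers an explanation for this result. Going by these compounds, it remains open whether an amine or a methoxy group on this carbon would separate from hydrogen in this assay. Compound 1 differs from compound 3 in more than one place, so the gap to compound 1 cannot be assigned to any single part.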